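The source may report more compounds than this note shows. Statements on the series, on what has been measured and on what is new or still open speak of the compounds shown alone.

Compound 1, with the structure `c1ccc(-c2ccc(Cn3cncc3CNc3ccc(-c4ccccc4)c(-c4ccccc4)c3)cc2)cc1`, is the starting point. In a toxicity assay on NIH3T3 cells (Mus musculus) for cytotoxicity, read by resazurin assay (on this read-out higher numbers stand for an effect only at larger amounts of compound and lower numbers for an effect already at smaller amounts), compound 1 gives > 10000 nM, which is a limit of the assay and not a measured number. Compound 3, with the structure `c1ccc(-c2ccc(Cn3cncc3CNc3ccc(-c4ccccc4)cc3)cc2)cc1`, is its closest neighbour among the measured compounds. In this assay compound 3 gives > 10000 nM, again a limit rather than a number. The resulting step that the two limits leave unreadable from compound 1 to compound 3 cannot be sized, since both ends sit at a limit. Compound 2, with the structure `COC(=O)c1ccc(NCc2cncn2Cc2cccc(OC)c2)cc1-c1ccccc1`, has "not determined" (no result reported) in this assay. So compound 1 stands at the limit of > 10000 nM in this assay, at which 2 of the 3 values shown sit, with no readable number among the three compounds.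

The next compound is compound 4, with the structure `c1ccc(-c2ccc(Cn3cncc3CNc3ccc(-c4noc5ccccc45)c(-c4ccccc4)c3)cc2)cc1`. It differs from compound 1 by a group of 9 heavy atoms (7 carbon, 1 nitrogen, 1 oxygen; one five-membered aromatic ring with 2 hetero atoms, one six-membered aromatic ring of carbon only) in place of a group of 6 heavy atoms (6 carbon; one six-membered aromatic ring of carbon only), on an aromatic carbon. Among the compounds with values here, no measured step gives a readable size for a change of this kind, and the only neighbour of compound 1 also sits at a limit. Compound 4 is therefore expected to show a step that the limit leaves unreadable from compound 1 to compound 4, that is, to remain at or close to the limit, with an estimated value of 20000 nM and a range from 8000 nM to 60000 nM.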

Compound 4, half-maximal effective concentration: > 10000 nM
Compound 4: a limit, no number; the forecaster's own chance of this, stated with the estimate: 75%; the middle value does not contradict the limit.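

In this assay compound 4 gives > 10000 nM, which is a limit and not a number. Compound 1 also sits at a limit, so the step between compound 1 and compound 4 cannot be read. The compounds shown leave open at what concentration any of them would affect these cells: the limit of > 10000 nM in this assay, at which 3 of the 4 values shown sit.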